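This account rests on a few compounds, and the source may have more. Where it says the series, first, only, none or still open, it means among the compounds named here.

Series so far, all in a functional assay on HL-60 cells (Homo sapiens) for antiproliferative activity, read by MTT assay, with a stated time of 72 h; on this read-out lower numbers stand for stronger inhibition and higher numbers for weaker inhibition (values follow):
- compound 1 `NC1=NC2(CCSCC2)N(OCCCOc2ccc(Cl)c(Cl)c2)C(N)=N1` gives 140 nM (halogenated aryl group)
- compound 2 `NC1=NC2(CCOCC2)N(OCCCOc2ccccc2)C(N)=N1` gives 2460 nM (unsubstituted phenyl)
- compound 3 `NC1=NC2(CCSCC2)N(OCCCOc2ccc(Br)cc2)C(N)=N1` gives 350 nM (halogenated aryl group)

Compound 2 has the highest number of the three, and its gap to each of the others lies beyond the scatter. The step of interest leads to compound 4 `NC1=NC2(CCOCC2)N(OCCCOc2ccccc2Cl)C(N)=N1` through chloro in place of hydrogen on an aromatic carbon on the phenyl, turning phenoxy into 2-chlorophenoxy.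

Within the data shown here, only one measured step bears on this, and only loosely: a 2.5-fold higher number from compound 1 to compound 3 (0.40 log units; beyond the scatter) exchanges one halogenated aryl group for another and is modest. Among the measured compounds shown here, no measured step adds a halogen to an unsubstituted phenyl. Compound 1 and compound 3 both carry halogen and lie lower than compound 2, but their core differs too, so that gap cannot be assigned to halogen alone.

A modest move towards a lower number is therefore expected in this assay. The estimated step is a 2.1-fold lower number from compound 2 to compound 4 (0.31 log units; beyond the scatter) and it remains uncertain. For compound 4 the estimated value is 1200 nM with an expected range from 450 nM to 3000 nM in this read-out.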

Compound 4, half-maximal inhibitory concentration: 660 nM
For compound 4 the middle estimate is 1.8-fold (0.26 log units) above the measured one; the range from low to high includes it.
By their numbers in this assay, from the lowest: compound 1; then compounds 3 and 4 (each within the scatter of the next); then compound 2.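

In this assay, among these compounds, chloro in place of hydrogen gives a 3.7-fold lower number from compound 2 to compound 4 (0.57 log units; beyond the scatter) and is the first measured step that adds a halogen to an unsubstituted phenyl. With the core of compound 2 kept unchanged, this step reads the chloro on its own, which the gap between compound 2 and the halogenated compounds 1 and 3 could not do, as their core differs too. No measurement shown accounts for the size of this step.

Open, from the compounds shown here alone, is whether the same change acts alike elsewhere on the phenyl or with the core of compound 1, and how a methoxy, an amine or a carboxylic acid would compare with chloro on this aromatic carbon. Also open, going by these compounds, is how much of the distance between compound 4 and compounds 1 and 3 belongs to the core, since they differ in more than one place.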